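Fluoro to chloro on a weakly active compound

The source may report more compounds than this note shows. Statements on the series, on what has been measured and on what is new or still open speak of the compounds shown alone.

Compound 1 `Cc1ccc(S(=O)(=O)Oc2ccccc2/C=C(\C#N)C(=O)Nc2nnc(C)s2)cc1`: 78%
Compound 2 `Cc1ccc(S(=O)(=O)Oc2ccccc2/C=C(\C#N)C(=O)Nc2nnc(Cc3ccccc3)s2)cc1`: 16%
Compound 3 `Cc1ccc(S(=O)(=O)Oc2ccccc2/C=C(\C#N)C(=O)Nc2nnc(Cc3ccc(F)cc3)s2)cc1`: "not active" (no number reported)

All three were tested in a functional assay on HL-60 cells (Homo sapiens) for inhibition, read by CCK-8 assay, with a stated time of 48 h, tested at 20 uM; on this read-out lower numbers stand for less inhibition of growth and higher numbers for more inhibition of growth at the one concentration tested. Compound 3 has no number on this scale, only the verdict "not active" (no number reported). Compound 4 `Cc1ccc(S(=O)(=O)Oc2ccccc2/C=C(\C#N)C(=O)Nc2nnc(Cc3ccc(Cl)cc3)s2)cc1` differs from it in one spot: chloro in place of fluoro on an aromatic carbon. Within the data shown here, no measured step covers this swap of chloro in place of fluoro. The closest evidence is the large step of a number 62 percentage points lower from compound 1 to compound 2 (beyond the scatter), which brought in the phenyl group that compound 3 and compound 4 also carry. Compound 4 is therefore expected to stay near compound 2 at 16%, with no step beyond the scatter expected from the level of compound 3. For compound 4 the estimated inhibition is 15%, with an expected range of 0% to 38%.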

Compound 4, percent growth inhibition at one concentration: 15%
Beside the measured number, compound 4's estimate shows no gap at the digits printed, within the range that was stated.
By their numbers in this assay, from the lowest: compounds 4 and 2 (each within the scatter of the next); then compound 1.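

In this assay, chloro on an aromatic carbon, para to a large group, leaves the benzyl compound where it was (a number 1 percentage points lower from compound 2 to compound 4 (within the scatter)), so this position gives no recovery of growth inhibition with chloro in place of hydrogen. The large gap to the compound without the aryl ring stays just as wide with 4-chlorophenyl as with plain phenyl (a number 63 percentage points lower from compound 1 to compound 4 (beyond the scatter)). The step from compound 3 cannot be read, and nothing shown explains these results. On these data alone, whether an amine or methoxy group at this spot, or an ethyl chain in place of the 4-chlorobenzyl, would restore activity remains open.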